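The source may hold more compounds than are shown below. What is called first, only, known or untested is meant among the compounds shown, and "the series" means these compounds.

Working notes on the uracil-derived triphosphate series.

Compound 1 `O=C(O)CCCO/N=c1/ccn([C@@H]2O[C@H](COP(=O)(O)OP(=O)(O)OP(=O)(O)O)[C@@H](O)[C@H]2O)c(=O)[nH]1` carries a carboxy-terminated chain on the oxime oxygen and in a functional assay on 1321-N1 cells for agonist activity at P2Y purinoceptor 6 (Homo sapiens), read by scintillation counting and inositol phosphate accumulation (on this read-out lower numbers stand for an effect already at smaller amounts and higher numbers for an effect only at larger amounts of compound), compound 1 gives 697 nM. Compound 2 `O=c1[nH]/c(=N\OCCCc2ccc(Br)cc2)ccn1[C@@H]1O[C@H](COP(=O)(O)OP(=O)(O)OP(=O)(O)O)[C@@H](O)[C@H]1O` carries a 4-bromophenyl at the same chain end and in this assay compound 2 gives 225 nM. Among the compounds with values here, the only step measured so far, a 3.1-fold lower number from compound 1 to compound 2 (0.49 log units; beyond the scatter), was modest but beyond the scatter. Within the data shown here, compound 2 therefore stands at the lowest of the two numbers, with compound 1 as its sole and nearest neighbour.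

Compound 3 `O=c1[nH]/c(=N\OCCCc2cccc([N+](=O)[O-])c2)ccn1[C@@H]1O[C@H](COP(=O)(O)OP(=O)(O)OP(=O)(O)O)[C@@H](O)[C@H]1O` differs from compound 2 by 3-nitrophenyl in place of 4-bromophenyl on a saturated chain carbon, three bonds along the chain from an oxygen. Among the measured compounds shown here, no measured step bears directly on an exchange of one aryl group for another; the step from compound 1 to compound 2 concerns the arrival of an aryl group in place of a carboxy, and it was modest. With the aryl group kept and only its substitution changed, the expected step of a 1.3-fold higher number from compound 2 to compound 3 (0.12 log units; within the scatter) is small, likely within the scatter. Compound 3 is estimated at 300 nM in this assay, within 100 nM to 900 nM.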

Compound 3, half-maximal effective concentration: 9700 nM
The estimate for compound 3 lay 32-fold (1.51 log units) below the measured number; measured number outside the range, above it.
By their numbers in this assay, from the lowest: compound 2; then compound 1; then compound 3.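

In this assay, the exchange on a saturated chain carbon, three bonds along the chain from an oxygen, gives a 43-fold higher number from compound 2 to compound 3 (1.63 log units; beyond the scatter), so this position responds strongly to which substituted phenyl it carries, not merely to the presence of an aryl ring. Replacing carboxy with an aryl group also has no single direction here: compound 2 gave a 3.1-fold lower number from compound 1 to compound 2 (0.49 log units; beyond the scatter), whereas the other aryl exchange gave a 14-fold higher number from compound 1 to compound 3 (1.14 log units; beyond the scatter), which places the carboxy-bearing compound between the two aryl compounds. Nothing available bears on the origin of this large gap between the two aryl groups.

The names 4-bromophenyl and 3-nitrophenyl differ in both the substituent and its place on the ring, so compound 2 and compound 3 alone cannot separate these two changes. Also open, as far as these compounds go, are where an unsubstituted phenyl at this chain end would fall relative to compound 2 and compound 3, and whether a longer chain would preserve the difference between the two aryl groups.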